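Aryl variation on the ethynyl substituent: compound 4

The source may report more compounds than this note shows. Statements on the series, on what has been measured and on what is new or still open speak of the compounds shown alone.

Three members of the series have been measured in an assay on CHO cells for displacement of a labelled ligand from adenosine receptor A3 (Homo sapiens), read by scintillation counting, with a stated time of 60 min; on this read-out higher numbers stand for weaker inhibition and lower numbers for stronger inhibition. Compound 1 `CNC(=O)[C@@]12C[C@@H]1[C@@H](n1cnc3c(NC)nc(C#Cc4ccc(CO)cc4)nc31)[C@H](O)[C@@H]2O` gives 2.16 nM. Compound 2 `CNC(=O)[C@@]12C[C@@H]1[C@@H](n1cnc3c(NC)nc(C#Cc4cccnc4)nc31)[C@H](O)[C@@H]2O` gives 2.15 nM in this assay, and compound 3 `CNC(=O)[C@@]12C[C@@H]1[C@@H](n1cnc3c(NC)nc(C#Cc4ncccn4)nc31)[C@H](O)[C@@H]2O` gives 1.97 nM. Compound 3 has the lowest of the three numbers, but its steps to compound 2 and to compound 1 both fall within the scatter, so the three compounds cannot be ordered.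

The three steps that exchange the group on the triple-bonded carbon are a 1.0-fold lower number from compound 1 to compound 2 (0.00 log units; within the scatter), a 1.1-fold lower number from compound 1 to compound 3 (0.04 log units; within the scatter) and a 1.1-fold lower number from compound 2 to compound 3 (0.04 log units; within the scatter). None of them moved the number beyond the scatter; single-ring carbon, one-nitrogen and two-nitrogen aromatics were equally tolerated.

Compound 4 `CNC(=O)[C@@]12C[C@@H]1[C@@H](n1cnc3c(NC)nc(C#Cc4cc5ccccc5o4)nc31)[C@H](O)[C@@H]2O` extends this exchange: 1-benzofuran-2-yl in place of pyrimidin-2-yl on a triple-bonded carbon. The entering group is larger than any so far and adds a second ring, which the measured steps do not cover. The bearing steps all being flat, no change beyond the scatter is expected in this assay, with the widened range reflecting the untested bicyclic.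

For compound 4 the expected value in this assay is 2.5 nM, between 0.8 nM and 8 nM, which means the step of a 1.3-fold higher number from compound 3 to compound 4 (0.10 log units; within the scatter) is expected.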

Compound 4, inhibition constant: 1.62 nM
Beside the measured number, compound 4's estimate is 1.5-fold (0.19 log units) above it; the range from low to high includes it.
By their numbers in this assay, from the lowest: compounds 4, 3, 2 and 1 (each within the scatter of the next).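

The 1-benzofuran-2-yl group puts a second aromatic ring and more heavy atoms than pyrimidin-2-yl on the triple-bonded carbon, a change the single-ring compounds did not cover, yet in this assay it separates compound 4 from none of them (a 1.2-fold lower number from compound 3 to compound 4 (0.08 log units; within the scatter); a 1.3-fold lower number from compound 2 to compound 4 (0.12 log units; within the scatter); a 1.3-fold lower number from compound 1 to compound 4 (0.12 log units; within the scatter)). Across these four compounds, with none going against it, this place therefore accepts a two-ring aromatic as readily as the single-ring groups, and the added ring and the exchange of two ring nitrogens for one ring oxygen leave no step beyond the scatter. No available measurement bears on why the number stays flat across these groups.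

On these data alone, all four compounds carry an aromatic ring on the triple-bonded carbon, so it remains open whether a saturated alkyl chain, a primary amine or a carboxylic acid would be accepted in that place. Also open, as far as these compounds go, is whether any group here can move the number beyond the scatter in this assay and whether this flatness extends to other adenosine receptors.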